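Swapping the anilino ring partner on a shared nitrile-bearing core

This account rests on a few compounds, and the source may have more. Where it says the series, first, only, none or still open, it means among the compounds named here.

Measured compounds:
- compound 1 `C#CCSc1nc(Nc2cccc(C(F)(F)F)c2)c(C#N)c(-c2ccccc2)n1`; in a functional assay on ECa-109 cells (Homo sapiens) for inhibition, read by MTT assay, with a stated time of 72 h (on this read-out lower numbers stand for stronger inhibition and higher numbers for weaker inhibition), compound 1 gives > 128000 nM
- compound 2 `N#Cc1c(Nc2ccc(Cl)cc2)nc(SCc2cn(Cc3ccccc3Cl)nn2)nc1-c1ccccc1`; in this assay compound 2 gives 1420 nM

The value for compound 1 is a limit of the assay and not a number, as the record states in the limit of > 128000 nM in this assay, at which 1 of the 2 values shown sits. Compound 2 therefore carries the only number shown in this assay, and nothing can be said about the gap between compound 1 and compound 2 beyond the fact that one is a limit.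

Compound 3 `Cc1ccccc1Nc1nc(SCc2cn(Cc3ccccc3Cl)nn2)nc(-c2ccccc2)c1C#N` has not yet been tested. It differs from compound 2 in one place: 2-methylphenyl in place of 4-chlorophenyl on a nitrogen on an aromatic ring. Among the compounds with values here, no step between two measured compounds is available to calibrate this change, so the expectation rests on compound 2 alone. A modest shift is expected, most likely toward weaker inhibition, but possibly staying within the usual scatter. For compound 3 the expected step is a 2.1-fold higher number from compound 2 to compound 3 (0.32 log units; beyond the scatter). In this assay compound 3 is estimated at 3000 nM, with a range from 800 nM to 12000 nM.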

Compound 3, half-maximal inhibitory concentration: 9740 nM
The estimate for compound 3 lay 3.2-fold (0.51 log units) below the measured number; the measured number falls inside the stated range.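

Within the data shown here, the pair of compound 2 and compound 3 gives the first step at this position in this assay: 2-methylphenyl in place of 4-chlorophenyl on a nitrogen on an aromatic ring goes with weaker inhibition (a 6.9-fold higher number from compound 2 to compound 3 (0.84 log units; beyond the scatter)). Among these compounds, the earlier compounds offered no step between two measured values, so this is the first sign that the group on this nitrogen changes the read-out while the rest of the molecule stays the same, and the step lies beyond the usual scatter even though both groups count 7 heavy atoms and one six-membered aromatic ring of carbon only. Nothing in the record speaks to why this step arises.

As far as these compounds go, whether the step follows the chlorine that leaves or the methyl that enters stays open, since the two change together in this single pair. From the compounds shown here alone, how a methoxy group or a fluorine on the same anilino ring would read in this assay also stays open, and with it whether the 4-chlorophenyl of compound 2 is a favourable choice or merely one point in a wider series.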